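Swapping 4-chlorobenzyl for 3-bromo-4-methoxybenzyl

The compounds below may be only part of what the source reports. "The series", "measured", "known", "first", "only" and "open" are said of these compounds alone.

In a functional assay on MGC-803 cells (Homo sapiens) for antiproliferative activity, read by MTT assay, with a stated time of 48 h (on this read-out higher numbers stand for weaker inhibition and lower numbers for stronger inhibition), compound 3 `COc1cc(N(Cc2ccc(Cl)cc2)C(=O)CSc2nc3ccccc3s2)cc(OC)c1OC` gives > 80000 nM, which is a limit of the assay and not a number. Compound 4 `COc1ccc(CN(C(=O)CSc2nc3ccccc3s2)c2cc(OC)c(OC)c(OC)c2)cc1Br` differs from it by 3-bromo-4-methoxyphenyl in place of 4-chlorophenyl on a saturated chain carbon bound to an amide-type nitrogen. The closest measured relatives are compound 1 `COc1ccc(CN(C(=O)CSc2nc3ccccc3s2)c2cc(OC)c(OC)c(OC)c2)cc1C`, at 6360 nM, and compound 2 `COc1ccc(CN(C(=O)CSc2nc3ccccc3s2)c2cc(OC)c(OC)c(OC)c2)cc1[N+](=O)[O-]`, at 682 nM, separated by a 9.3-fold lower number from compound 1 to compound 2 (0.97 log units; beyond the scatter). Moving to 4-chlorophenyl brought large steps, namely an at least 12-fold higher number from compound 1 to compound 3 (1.09 log units; beyond the scatter) and an at least 110-fold higher number from compound 2 to compound 3 (2.06 log units; beyond the scatter). The reverse change should therefore bring a large step down in this assay, and the expected result is an at least 32-fold lower number from compound 3 to compound 4 (1.50 log units; beyond the scatter). Compound 4 is estimated at 2500 nM, with an expected range from 500 nM to 12000 nM.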

Compound 4, half-maximal inhibitory concentration: 852 nM
The estimate for compound 4 lay 2.9-fold (0.47 log units) above the measured number, and the stated range covers the measured number.
By their numbers in this assay, from the lowest: compounds 2 and 4 (each within the scatter of the next); then compound 1. At a limit, above all of these: compound 3.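

In this assay, bromo and nitro on this aromatic carbon cannot be told apart, with a 1.2-fold higher number from compound 2 to compound 4 (0.10 log units; within the scatter), while bromo in place of methyl gives a 7.5-fold lower number from compound 1 to compound 4 (0.87 log units; beyond the scatter). The full change from 4-chlorobenzyl to 3-bromo-4-methoxybenzyl gives an at least 93-fold lower number from compound 3 to compound 4 (1.97 log units; beyond the scatter). The value of compound 3 is a limit of the assay and not a number: the limit of > 80000 nM in this assay, at which 1 of the 4 values shown sits.

Whether the methoxy group, the bromo group or both together account for that step stays open. Also open, from the compounds shown here alone, is how an amine or a carboxylic acid in place of bromo would read.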